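Swapping Chlorine and Methyl Positions on the Aryl Triazole

The source may hold more compounds than are shown below. What is called first, only, known or untested is meant among the compounds shown, and "the series" means these compounds.

Two measured compounds frame this step. Compound 2, `Cc1ccc(-n2nncc2CN2C(=O)C3(C(C#N)=C(N)Oc4c(N)cc5nc6ccccc6nc5c43)c3ccccc32)cc1Cl`, carries a 3-chloro-4-methylphenyl group on an aromatic nitrogen of the shared core. In a functional assay on HepG2 cells (Homo sapiens) for antiproliferative activity, read by MTT assay, with a stated time of 48 h (on this read-out lower numbers stand for stronger inhibition and higher numbers for weaker inhibition), compound 2 gives > 50000 nM, which is a limit of the assay rather than a number. Compound 1, `COc1ccccc1-n1nncc1CN1C(=O)C2(C(C#N)=C(N)Oc3c(N)cc4nc5ccccc5nc4c32)c2ccccc21`, differs only in bearing a 2-methoxyphenyl group on that aromatic nitrogen. In this assay compound 1 gives > 50000 nM, again a limit. The step that the two limits leave unreadable from compound 1 to compound 2 cannot be read in size. Compound 3, `Cc1ccc(Cl)cc1-n1nncc1CN1C(=O)C2(C(C#N)=C(N)Oc3c(N)cc4nc5ccccc5nc4c32)c2ccccc21`, is the next compound: 5-chloro-2-methylphenyl in place of 3-chloro-4-methylphenyl on an aromatic nitrogen. Within the data shown here, the only measured step, from compound 1 to compound 2, gives no readable size, and both values sit at the same limit (the limit of > 50000 nM in this assay, at which 2 of the 2 values shown sit). The expected step is a step that the limit leaves unreadable from compound 2 to compound 3, nothing beyond the scatter, with compound 3 most likely remaining at the limit. The estimate for compound 3 in this assay is 60000 nM, within 20000 nM to 200000 nM.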

Compound 3, half-maximal inhibitory concentration: 17300 nM
The estimate for compound 3 lay 3.5-fold (0.54 log units) above the measured number; measured number outside the range, below it.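

In this assay, exchanging 3-chloro-4-methylphenyl for 5-chloro-2-methylphenyl gives an at least 2.8-fold lower number from compound 2 to compound 3 (0.46 log units; beyond the scatter). The two groups have the same atoms, so the arrangement of chlorine and methyl on this ring alone can change the read-out, which the earlier pair could not show. Exchanging 2-methoxyphenyl for the same group gives an at least 2.8-fold lower number from compound 1 to compound 3 (0.46 log units; beyond the scatter), and both sizes are minimums because each starting value is a limit, not a number: the limit of > 50000 nM in this assay, at which 2 of the 3 values shown sit.

The chlorine and the methyl both change place in this single step, so the compounds shown do not tell which of the two matters. Also open, from the compounds shown here alone, is what this ring would give with only the methyl, or with an amine or a carboxylic acid in place of the chlorine.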